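The source may report more compounds than this note shows. Statements on the series, on what has been measured and on what is new or still open speak of the compounds shown alone.

Measured so far:

Compound 1 `O=C1c2ccccc2C(=O)N1CCOC(=S)N(C(=O)c1ccc([N+](=O)[O-])cc1Cl)c1ccc(Cl)cc1` gives 19000 nM in an ADME assay on MT4 cells (Homo sapiens) for cytotoxicity, read by MTT assay; on this read-out higher numbers stand for lower toxicity in this test and lower numbers for higher toxicity in this test.
Compound 2 `O=C1c2ccccc2C(=O)N1CCOC(=S)N(C(=O)c1ccc(Cl)c([N+](=O)[O-])c1)c1ccc(Cl)cc1` gives 48000 nM in this assay.
Compound 3 `Cc1ccc(N(C(=O)c2ccc([N+](=O)[O-])cc2Cl)C(=S)OCCN2C(=O)c3ccccc3C2=O)cc1` gives 17000 nM in this assay.

Two single changes link these three compounds. The first, (4-chloro-3-nitrophenyl in place of 2-chloro-4-nitrophenyl on a carbonyl carbon), gave a 2.5-fold higher number from compound 1 to compound 2 (0.40 log units; beyond the scatter). The second, (methyl in place of chloro on an aromatic carbon), gave a 1.1-fold lower number from compound 1 to compound 3 (0.05 log units; within the scatter), so compound 1 and compound 3 cannot be told apart on this read-out.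

Compound 4 `Cc1ccc(N(C(=O)c2ccc(Cl)c([N+](=O)[O-])c2)C(=S)OCCN2C(=O)c3ccccc3C2=O)cc1` is not yet measured in this assay. It differs from compound 3 by 4-chloro-3-nitrophenyl in place of 2-chloro-4-nitrophenyl on a carbonyl carbon, and this is the same change already made from compound 1 to compound 2, where the place around the change is described in the same words. Compound 3 and compound 1 differ only in their cores, as given by methyl in place of chloro on an aromatic carbon. On the basis of the step of a 2.5-fold higher number from compound 1 to compound 2 (0.40 log units; beyond the scatter), a step of similar size is expected from compound 3 to compound 4, namely a 2.5-fold higher number from compound 3 to compound 4 (0.39 log units; beyond the scatter). Compound 4 is therefore estimated to give 42000 nM in this assay, with a likely range from 20000 nM to 85000 nM, resting on one earlier occurrence of this change only.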

Compound 4, half-maximal cytotoxic concentration: 47000 nM
Beside the measured number, compound 4's estimate is 1.1-fold (0.05 log units) below it; low and high end bracket the measured number.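

In this assay, 4-chloro-3-nitrophenyl in place of 2-chloro-4-nitrophenyl on a carbonyl carbon gave a 2.8-fold higher number from compound 3 to compound 4 (0.44 log units; beyond the scatter), so the step seen on the core of compound 1 was found again on the core of compound 3: the same change on two cores in this assay, a 2.5-fold higher number (0.40 log units; beyond the scatter) from compound 1 to compound 2 and a 2.8-fold higher number (0.44 log units; beyond the scatter) from compound 3 to compound 4, 1.1-fold (0.04 log units) apart, within the scatter of two such steps Methyl in place of chloro on an aromatic carbon gave a 1.0-fold lower number from compound 2 to compound 4 (0.01 log units; within the scatter), which leaves that change without a readable effect with either chloro-nitrophenyl group: the same change on two cores in this assay, a 1.1-fold lower number (0.05 log units; within the scatter) from compound 1 to compound 3 and a 1.0-fold lower number (0.01 log units; within the scatter) from compound 2 to compound 4, 1.1-fold (0.04 log units) apart, within the scatter of two such steps Together these steps show that, across these four compounds, each change carried over from one core to the other, but two occurrences of each do not show that this would hold on any further core, and they do not explain the step.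

Going by these compounds, it remains open whether the step would persist with an amine or a methoxy group in place of the methyl or chloro. A carboxylic acid in place of the nitro group, or a longer chain in the linker, is equally untested by these compounds.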